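Notes on a fluoro-for-nitro exchange in a weak series

The source may report more compounds than this note shows. Statements on the series, on what has been measured and on what is new or still open speak of the compounds shown alone.

Measured compounds:
compound 1, `O=[N+]([O-])c1ccccc1Nc1nc(-c2ccncc2)cs1`, 40700 nM
compound 2, `Cc1cccc(Nc2nc(-c3ccncc3-c3ccc(C(F)(F)F)cc3)cs2)c1`, 12800 nM; 12900 nM (2 entries)

In a functional assay on RCC4 cells (Homo sapiens) for inhibition, read by XTT assay, with a stated time of 4 days (a lower number here means a stronger inhibitor, a higher number a weaker inhibitor), compound 1 gives 40700 nM, the highest number shown, with one further entry that carries no single number. In this assay compound 2 gives 12800 nM; 12900 nM (2 entries), a lower number, but it differs from compound 1 in more than one place; its repeat entries agree closely (the several entries of compound 2 in this assay, 12800 nM; 12900 nM (2 entries)). Compound 3, `Fc1ccccc1Nc1nc(-c2ccncc2)cs1`, is not yet measured and carries fluoro in place of nitro on an aromatic carbon. Among the measured compounds shown here, no single-change step is available to size this exchange, so no shift beyond the usual scatter is expected, and the step of a 1.2-fold lower number from compound 1 to compound 3 (0.07 log units; within the scatter) is estimated as essentially flat. Compound 3 is expected to give about 35000 nM, within 12000 nM to 100000 nM.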

Compound 3, half-maximal inhibitory concentration: 14500 nM
Estimate against measurement, compound 3: 2.4-fold (0.38 log units) above; low and high end bracket the measured number.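

This position, on an aromatic carbon ortho to a large group, responds to a single exchange: in this assay, fluoro in place of nitro gives a 2.8-fold lower number from compound 1 to compound 3 (0.45 log units; beyond the scatter), a modest gain and the first size available for any single change in the series. The step can be read against repeat entries that agree closely: the several entries of compound 2 in this assay, 12800 nM; 12900 nM (2 entries)

As far as these compounds go, whether the lower number follows from losing nitro or from gaining fluoro stays open. Also open, from the compounds shown here alone, is how this position responds to other groups, such as an amine or a carboxylic acid.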